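A nitro group added to compound 2

The source may hold more compounds than are shown below. What is called first, only, known or untested is meant among the compounds shown, and "the series" means these compounds.

Compound 1 `O=C(CCCCC1CCSS1)Nc1ccccc1Cl`: "not active" (no number reported)
Compound 2 `O=C(CCCCC1CCSS1)Nc1cccc(C(F)(F)F)c1`: 74.8%

Among the compounds with values here, in a functional assay on HO8910 cells (Homo sapiens) for inhibition, read by MTT assay, with a stated time of 24 h, tested at 100 ug/mL (on this read-out higher numbers stand for more inhibition of growth at the one concentration tested and lower numbers for less inhibition of growth), compound 2 gives 74.8% and holds the only number so far. Within the data shown here, the one other entry, for compound 1, carries no number, so no measured step is available as a guide.

Compound 3 `O=C(CCCCC1CCSS1)Nc1ccc([N+](=O)[O-])c(C(F)(F)F)c1` differs from compound 2 by a single change nitro in place of hydrogen on an aromatic carbon with nitro in place of hydrogen on an aromatic carbon, ortho to a trifluoromethyl group and para to a large group.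

The reading of compound 2 at 74.8% leaves limited room upward, so a fall of moderate size is expected, though with wide uncertainty. The expected change is a number 14.8 percentage points lower from compound 2 to compound 3 (beyond the scatter) and rests on this single number. In this assay the estimate for compound 3 is 60% (expected range 30% to 85%).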

Compound 3, percent growth inhibition at one concentration: 47.7%
Compound 3: middle estimate off by 12.3 percentage points, on the high side; low and high end bracket the measured number.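

In this assay, within the data shown here, the step of a number 27.1 percentage points lower from compound 2 to compound 3 (beyond the scatter) is the first measured step, and it concerns the aromatic carbon ortho to a trifluoromethyl group and para to a large group. It shows that this position, which carries hydrogen in compound 2, does not tolerate nitro without loss: growth inhibition falls, though compound 3 still gives a reported number. Nothing measured here explains the fall.

The compounds shown leave open whether the fall belongs to nitro itself or would follow any group placed here, such as an amine, a nitrile or a carboxylic acid. They also leave open whether nitro would have the same effect without the trifluoromethyl group on the neighbouring carbon's side of the ring, since this single step is the only case at hand.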